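Swapping the aniline ring: compound 3 to compound 4

The source may hold more compounds than are shown below. What is called first, only, known or untested is meant among the compounds shown, and "the series" means these compounds.

Measured compounds in a functional assay on MGC-803 cells (Homo sapiens) for inhibition, read by MTT assay, with a stated time of 72 h; on this read-out higher numbers stand for weaker inhibition and lower numbers for stronger inhibition:
compound 1, `O=C(CSc1nc(Nc2ccccc2)c2ccccc2n1)Nc1cccc(Cl)c1`, 14300 nM
compound 2, `O=C(CSc1nc(Nc2ccccc2)c2ccccc2n1)Nc1ccc(Cl)c(Cl)c1`, 37900 nM
compound 3, `C=CC(=O)Nc1cccc(NC(=O)CSc2nc(Nc3ccccc3F)c3ccccc3n2)c1`, 26100 nM

Compound 3 stands second highest of the three numbers in this assay. Its nearest neighbour is compound 2, a gap that lies within the scatter, and its gap to compound 1 also lies within the scatter, so no order among the three can be claimed.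

Compound 4, `C=CC(=O)Nc1cccc(NC(=O)CSc2nc(Nc3cccc(Cl)c3)c3ccccc3n2)c1`, differs from compound 3 by 3-chlorophenyl in place of 2-fluorophenyl on a nitrogen on an aromatic ring. Within the data shown here, the single step measured so far, a 2.7-fold higher number from compound 1 to compound 2 (0.42 log units; beyond the scatter), concerns a chloro added on the amide-side ring, not the ring on the aromatic nitrogen, and so does not bear directly on this change. Among the measured compounds shown here, with no measured step at the place in question, compound 4 is expected to give a number close to that of compound 3, with the step of a 1.1-fold lower number from compound 3 to compound 4 (0.04 log units; within the scatter) expected to remain within the scatter. Compound 4 is therefore estimated at 24000 nM, within a range from 9000 nM to 60000 nM.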

Compound 4, half-maximal inhibitory concentration: 7830 nM
Compound 4: the middle estimate sits 3.1-fold (0.49 log units) above what was measured; measured number below the stated range.
By their numbers in this assay, from the lowest: compounds 4, 1, 3 and 2 (each within the scatter of the next, the first and the last beyond it).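

In this assay, among these compounds, the exchange of 2-fluorophenyl for 3-chlorophenyl on the nitrogen gives a 3.3-fold lower number from compound 3 to compound 4 (0.52 log units; beyond the scatter) and is the first step measured at this place, showing that the ring there can shift the number beyond the scatter. The change alters both the halogen and its place on the ring, so this single step cannot show which of the two matters. No measurement available here accounts for the step.

From the compounds shown here alone, it remains open whether 3-fluorophenyl or 2-chlorophenyl on the same nitrogen would read closer to compound 3 or to compound 4, which would separate the two alterations. Also open, going by these compounds, is how a methoxy group or an amine on that ring would read against the halogens.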